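Trifluoromethyl for methoxy on the aryl hydrazone of compound 3

A few compounds are considered here, and "the series" means these few. Any claim that something is new, unique, unknown or untested is made for them only; others in the source may bear on it.

Of the compounds shown here, three share one core and have been measured in a functional assay on MDA-MB-231 cells (Homo sapiens) for cytotoxicity, read by MTT assay, with a stated time of 72 h; on this read-out lower numbers stand for stronger inhibition and higher numbers for weaker inhibition. Compound 1 `COc1ccc(/C=N/NC(=O)Nc2ccc(Oc3ccnc4cc(OCCCN5CCCCC5)c(OC)cc34)c(F)c2)cc1` gives 840 nM in this assay. Compound 2 `COc1cc2c(Oc3ccc(NC(=O)N/N=C/c4ccc(C(F)(F)F)cc4)cc3F)ccnc2cc1OCCCN1CCCCC1` gives 1100 nM, and compound 3 `COc1ccc(/C=N/NC(=O)Nc2ccc(Oc3ccnc4cc(OCCCN5CCC(C)CC5)c(OC)cc34)c(F)c2)cc1` gives 1000 nM. The step of a 1.3-fold higher number from compound 1 to compound 2 (0.12 log units; within the scatter) and the step of a 1.2-fold higher number from compound 1 to compound 3 (0.08 log units; within the scatter) both stay within the scatter, so the three numbers cannot be ordered with confidence; compound 3 sits with compound 2 and compound 1 in one narrow band.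

Compound 4 `COc1cc2c(Oc3ccc(NC(=O)N/N=C/c4ccc(C(F)(F)F)cc4)cc3F)ccnc2cc1OCCCN1CCC(C)CC1` differs from compound 3 by trifluoromethyl in place of methoxy on an aromatic carbon. Among the measured compounds shown here, the only measured step with the same change is a 1.3-fold higher number from compound 1 to compound 2 (0.12 log units; within the scatter), which was within the scatter and went toward a higher number. The other measured step, a 1.2-fold higher number from compound 1 to compound 3 (0.08 log units; within the scatter), also stays within the scatter. Compound 4 is therefore expected to show a step of a 1.3-fold higher number from compound 3 to compound 4 (0.11 log units; within the scatter) in this assay, small and toward a higher number, if any. For compound 4 the estimate is 1300 nM, within a range from 650 nM to 2600 nM.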

Compound 4, half-maximal inhibitory concentration: 1300 nM
Compound 4: the middle estimate sits on the measured number at the digits printed; the measured number falls inside the stated range.
By their numbers in this assay, from the lowest: compounds 1, 3, 2 and 4 (each within the scatter of the next).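

In this assay, the change from 4-methoxyphenyl to 4-(trifluoromethyl)phenyl now has a second reading, on the core of compound 3, where it gives a 1.3-fold higher number from compound 3 to compound 4 (0.11 log units; within the scatter), and it matches the first reading: the same change on two cores in this assay, a 1.3-fold higher number (0.12 log units; within the scatter) from compound 1 to compound 2 and a 1.3-fold higher number (0.11 log units; within the scatter) from compound 3 to compound 4, 1.0-fold (0.00 log units) apart, within the scatter of two such steps

The methyl on the saturated ring carbon also has a second reading, now with trifluoromethyl in place of methoxy, where it gives a 1.2-fold higher number from compound 2 to compound 4 (0.07 log units; within the scatter): the same change on two cores in this assay, a 1.2-fold higher number (0.08 log units; within the scatter) from compound 1 to compound 3 and a 1.2-fold higher number (0.07 log units; within the scatter) from compound 2 to compound 4, 1.0-fold (0.00 log units) apart, within the scatter of two such steps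

Across these four compounds, each of the two changes therefore stays within the scatter on both cores it was read on, and no compound goes against this.

All of the steps shown stay within the scatter, so these compounds do not show what would move the number further. On these data alone, it remains open whether an amine or a carboxylic acid on the aromatic carbon para to a large group, or a longer chain on the saturated ring carbon, would give a step beyond the scatter.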